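The source may hold more compounds than are shown below. What is called first, only, known or untested is meant among the compounds shown, and "the series" means these compounds.

Measured compounds:
compound 1, `N#CC1(c2cc(CCO)cc(-c3ccnc4[nH]nc(C(F)(F)F)c34)c2)CC1`: 25 nM
compound 2, `CC(C)C(O)Cc1cc(-c2ccnc3[nH]nc(C(F)(F)F)c23)cc(C2(C#N)CC2)c1`: 215 nM
compound 3, `N#CC1(c2cc(CC(=O)O)cc(-c3ccnc4[nH]nc(C(F)(F)F)c34)c2)CC1`: 446 nM

All three were tested in an assay on isolated protein for inhibition of protein kinase C epsilon type (Homo sapiens), read by coupled enzyme assay; a lower number here means a stronger inhibitor, a higher number a weaker inhibitor. Compound 2 stands second highest of the three numbers; its nearest neighbour is compound 3, reached by a 2.1-fold higher number from compound 2 to compound 3 (0.32 log units; beyond the scatter), and its furthest is compound 1, from which it is separated by an 8.6-fold higher number from compound 1 to compound 2 (0.93 log units; beyond the scatter). Compound 3 differs from compound 1 by an 18-fold higher number from compound 1 to compound 3 (1.25 log units; beyond the scatter).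

The next compound, compound 4, `N#CC1(c2cc(CCF)cc(-c3ccnc4[nH]nc(C(F)(F)F)c34)c2)CC1`, is a variation on compound 2 at the same position:

fluoromethyl in place of 1-hydroxy-2-methylpropyl on a saturated chain carbon bound to an aromatic carbon

Among the compounds with values here, two measured steps bear on this change. The step from compound 1 to compound 2, an 8.6-fold higher number from compound 1 to compound 2 (0.93 log units; beyond the scatter), shows the cost of adding isopropyl at this chain, and compound 4 gives up that isopropyl again. The steps to compound 3, an 18-fold higher number from compound 1 to compound 3 (1.25 log units; beyond the scatter) and a 2.1-fold higher number from compound 2 to compound 3 (0.32 log units; beyond the scatter), show that this chain position is sensitive to what is placed there, and that carboxy in place of hydroxymethyl is the least favourable of the measured options. Within the data shown here, there is no measured step for fluoromethyl in place of a hydroxyl-bearing group, so that part of the change carries no precedent. Compound 4 is expected to improve on compound 2 by a 3.1-fold lower number from compound 2 to compound 4 (0.49 log units; beyond the scatter), on the reasoning that removing the isopropyl recovers part of an 8.6-fold higher number from compound 1 to compound 2 (0.93 log units; beyond the scatter). The estimate for compound 4 in this assay is 70 nM, with a range from 18 nM to 280 nM.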

Compound 4, inhibition constant: 90 nM
Compound 4: middle estimate off by 1.3-fold (0.11 log units), on the low side; the measured number falls inside the stated range.
By their numbers in this assay, from the lowest: compound 1; then compound 4; then compound 2; then compound 3.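

In this assay, 2-fluoroethyl in place of 2-hydroxy-3-methylbutyl gives a 2.4-fold lower number from compound 2 to compound 4 (0.38 log units; beyond the scatter), and fluoromethyl in place of carboxy gives a 5.0-fold lower number from compound 3 to compound 4 (0.70 log units; beyond the scatter), so a chain without a hydroxy group can still stand ahead of two of the measured options at this position. The new comparison is the one on the short chain, where only the end group changes: fluoro in place of hydroxy gives a 3.6-fold higher number from compound 1 to compound 4 (0.56 log units; beyond the scatter), which shows that the hydroxy group of compound 1 cannot be exchanged for fluoro at no cost and that dropping the isopropyl does not by itself restore the lowest number of the series. Nothing in the material available explains why the numbers move in this way.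

As far as these compounds go, it remains open whether an amine or a methoxy group at the end of this short chain would stay as close to compound 1 as the hydroxy-bearing chain does or fall back towards compound 4. A longer unbranched chain ending in hydroxy is also untested by these compounds, so they cannot say how far the chain itself can grow before the number rises.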